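Ethoxy for methoxy on a thiophene-bearing pyridine nitrile

A few compounds are considered here, and "the series" means these few. Any claim that something is new, unique, unknown or untested is made for them only; others in the source may bear on it.

Three compounds share one core and differ at two places. Compound 1 `COc1nc(-c2ccc(Cl)cc2)cc(-c2ccc(Cl)cc2Cl)c1C#N` carries a methoxy group and a 4-chlorophenyl group; in a functional assay on trachea (Cavia porcellus) for activation (a higher number here means a weaker inhibitor, a lower number a stronger inhibitor), compound 1 gives 7550 nM. Compound 2 `CCOc1nc(-c2ccc(Cl)cc2)cc(-c2ccc(Cl)cc2Cl)c1C#N` differs by methyl in place of hydrogen on a saturated chain carbon bound to an oxygen on an aromatic ring and in this assay compound 2 gives 9380 nM, a change of a 1.2-fold higher number from compound 1 to compound 2 (0.09 log units; within the scatter). Compound 3 `COc1nc(-c2cccs2)cc(-c2ccc(Cl)cc2Cl)c1C#N` differs from compound 1 by thiophen-2-yl in place of 4-chlorophenyl on an aromatic carbon; in this assay compound 3 gives 3280 nM, a change of a 2.3-fold lower number from compound 1 to compound 3 (0.36 log units; beyond the scatter).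

Compound 4 `CCOc1nc(-c2cccs2)cc(-c2ccc(Cl)cc2Cl)c1C#N` is not yet measured. It differs from compound 3 by methyl in place of hydrogen on a saturated chain carbon bound to an oxygen on an aromatic ring, the same kind of change as that from compound 1 to compound 2, at the same place. Because a 1.2-fold higher number from compound 1 to compound 2 (0.09 log units; within the scatter) stayed within the scatter, the step from compound 3 to compound 4 is expected to be small, about a 1.2-fold higher number from compound 3 to compound 4 (0.08 log units; within the scatter). Compound 4 is therefore estimated at 3900 nM in this assay, likely between 2000 nM and 8000 nM.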

Compound 4, half-maximal inhibitory concentration: 8710 nM
Compound 4: the middle estimate sits 2.2-fold (0.35 log units) below what was measured, and the stated range ends below it.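

On the core bearing thiophen-2-yl, ethoxy in place of methoxy gives a 2.7-fold higher number from compound 3 to compound 4 (0.42 log units; beyond the scatter), yet this step cannot be told apart from the one on the core of compound 1: the same change on two cores in this assay, a 1.2-fold higher number (0.09 log units; within the scatter) from compound 1 to compound 2 and a 2.7-fold higher number (0.42 log units; beyond the scatter) from compound 3 to compound 4, 2.1-fold (0.33 log units) apart, within the scatter of two such steps. With ethoxy in place, thiophen-2-yl for 4-chlorophenyl gives a 1.1-fold lower number from compound 2 to compound 4 (0.03 log units; within the scatter), and this step likewise cannot be told apart from its counterpart with methoxy: the same change on two cores in this assay, a 2.3-fold lower number (0.36 log units; beyond the scatter) from compound 1 to compound 3 and a 1.1-fold lower number (0.03 log units; within the scatter) from compound 2 to compound 4, 2.1-fold (0.33 log units) apart, within the scatter of two such steps. Each change may therefore carry from one core to the other, but a single pair of steps neither proves that nor shows that the core matters.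

Still open, from the compounds shown here alone, is how a longer chain, such as propoxy, or an amine in place of the ethoxy group would behave in this assay. Going by these compounds, whether either step holds on further cores is also open.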